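The compounds below may be only part of what the source reports. "The series", "measured", "known", "first", "only" and "open" are said of these compounds alone.

Three analogues sharing the core of compound 1 `Cc1ccc(NC(=O)CS(=O)(=O)c2nccc(Oc3c(C)cc(C#N)cc3C)n2)cc1` have numbers in an ADME assay on MT4 cells (Homo sapiens) for cytotoxicity, read by MTT assay, with a stated time of 4 days; a lower number here means that less compound is tolerated, a higher number that more compound is tolerated. Compound 1 gives 7490 nM, the lowest of the three; compound 2 `Cc1ccc(NC(=O)CS(=O)(=O)c2nccc(Oc3c(C)cc(C#N)cc3C)n2)cc1C` gives 13900 nM and compound 3 `Cc1cc(C#N)cc(C)c1Oc1ccnc(S(=O)(=O)CC(=O)Nc2cccc(F)c2)n1` gives 25900 nM. The step of a 1.9-fold higher number from compound 1 to compound 2 (0.27 log units; within the scatter) stays within the scatter, a 3.5-fold higher number from compound 1 to compound 3 (0.54 log units; beyond the scatter) goes beyond it, and a 1.9-fold higher number from compound 2 to compound 3 (0.27 log units; within the scatter) falls within it. Compound 4 `Cc1cc(C#N)cc(C)c1Oc1ccnc(S(=O)(=O)CC(=O)Nc2ccc(Cl)cc2)n1` differs from compound 1 by chloro in place of methyl on an aromatic carbon. Among the compounds with values here, no measured step exchanges a single substituent on the 4-methylphenyl group; the nearest comparison is the exchange of the whole aryl group, a 3.5-fold higher number from compound 1 to compound 3 (0.54 log units; beyond the scatter), which shifted the number only modestly. A step in this assay of at most that size, towards a higher number or none beyond the scatter, is expected, giving a 1.3-fold higher number from compound 1 to compound 4 (0.13 log units; within the scatter). Compound 4 is therefore estimated at 10000 nM, with a range of 4000 nM to 25000 nM.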

Compound 4, half-maximal cytotoxic concentration: 16600 nM
Beside the measured number, compound 4's estimate is 1.7-fold (0.22 log units) below it; measured number inside the range.
By their numbers in this assay, from the lowest: compounds 1, 2, 4 and 3 (each within the scatter of the next, the first and the last beyond it).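

Chloro in place of methyl on the aromatic carbon is the first exchange of a single substituent on the 4-methylphenyl group, and in this assay it gives a 2.2-fold higher number from compound 1 to compound 4 (0.35 log units; beyond the scatter), so one heavy atom at this position is enough to pass the scatter. The exchanges of the whole aryl group, a 1.6-fold lower number from compound 3 to compound 4 (0.19 log units; within the scatter) and a 1.2-fold higher number from compound 2 to compound 4 (0.08 log units; within the scatter), stay within the scatter, leaving compound 2, compound 3 and compound 4 unseparated. Nothing at hand bears on the origin of these steps.

Open, from the compounds shown here alone, is how an amine, a methoxy group or a carboxylic acid on that same aromatic carbon would read in this assay.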